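Exchanging Acetyl for Dimethylamino on Compound 1

The source may report more compounds than this note shows. Statements on the series, on what has been measured and on what is new or still open speak of the compounds shown alone.

Measured compounds:
compound 1 `COc1cc(C)cc(-c2c(-c3ccnc(-c4ccc(C(C)=O)cc4)c3)cnn2CC#N)c1` — > 100000 nM
compound 2 `COc1cc(C)cc(-c2nn(CC#N)cc2-c2ccc(-c3cccc(C(C)=O)c3)nc2)c1` — 11500 nM
compound 3 `Cc1cc(O)cc(-c2nn(CC#N)cc2-c2ccnc(-c3ccc(N(C)C)cc3)c2)c1` — 57800 nM

Three compounds sharing the same core were tested in a functional assay on TK-10 cells (Homo sapiens) for inhibition, read by sulforhodamine B assay, with a stated time of 48 h; on this read-out higher numbers stand for weaker inhibition of growth and lower numbers for stronger inhibition of growth. Compound 1 stands apart in that its result is only a limit of the assay and not a number; it sits at the limit of > 100000 nM in this assay, at which 1 of the 3 values shown sits. Compound 2, which carries its acetyl group on a different position of its six-membered aromatic ring of carbon only, gives 11500 nM in this assay. Compound 3, which carries a dimethylamino group together with a hydroxy group in place of the methoxy group, gives 57800 nM in this assay. No pair among these three differs in only one place, so no single step can be read from them.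

Compound 4 `COc1cc(C)cc(-c2c(-c3ccnc(-c4ccc(N(C)C)cc4)c3)cnn2CC#N)c1` has not yet been measured. It differs from compound 1 by dimethylamino in place of acetyl on an aromatic carbon. Since the value for compound 1 is a limit, the step to compound 4 cannot be fixed; the step from compound 1 to compound 4 is expected to be an at least 1.6-fold lower number from compound 1 to compound 4 (0.22 log units; that floor lies within the scatter), leaning toward stronger inhibition of growth, though it may well fall within the scatter. Compound 4 is therefore expected to give about 60000 nM in this assay, with a plausible range from 20000 nM to 200000 nM.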

Compound 4, concentration for total growth inhibition: > 100000 nM
Compound 4 ended at the assay's limit; the forecaster's own chance of this, stated with the estimate: 35%; middle value at least 1.6-fold (0.22 log units) away from the limit.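

In this assay compound 1 and compound 4 each give a limit and not a number, so no step between them can be read: the limit of > 100000 nM in this assay, at which 2 of the 4 values shown sit.

The compounds shown leave open whether dimethylamino in place of acetyl on the shared core changes the inhibition of growth at all, and in which direction.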